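This account rests on a few compounds, and the source may have more. Where it says the series, first, only, none or still open, it means among the compounds named here.

Working notes on the substituent at the ring nitrogen, read in an ADME assay on HEK293 cells (Homo sapiens) for cytotoxicity; a lower number here means a stronger inhibitor, a higher number a weaker inhibitor. Compound 1 `CCC(=O)N1C[C@H](NC(=O)c2ccc(-n3ccccc3=O)cc2)[C@H](NC(=O)c2ccc(Cl)s2)C1` gives only a limit, > 100000 nM. Compound 2 `COCC(=O)N1C[C@H](NC(=O)c2ccc(-n3ccccc3=O)cc2)[C@H](NC(=O)c2ccc(Cl)s2)C1` also gives only a limit, > 100000 nM. Compound 3 `COCCOC(=O)N1C[C@H](NC(=O)c2ccc(-n3ccccc3=O)cc2)[C@H](NC(=O)c2ccc(Cl)s2)C1` gives a limit as well, > 100000 nM. Compound 3 therefore has no number of its own and shares its position with the other two, as the limit of > 100000 nM in this assay, at which 3 of the 3 values shown sit, shows.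

Compound 4 `CS(=O)(=O)N1C[C@H](NC(=O)c2ccc(-n3ccccc3=O)cc2)[C@H](NC(=O)c2ccc(Cl)s2)C1` carries methylsulfonyl in place of (2-methoxyethoxy)carbonyl on an amine nitrogen in a ring.

Among the measured compounds shown here, three measured steps bear on this change: a step that the two limits leave unreadable from compound 1 to compound 2, a step that the two limits leave unreadable from compound 1 to compound 3 and a step that the two limits leave unreadable from compound 2 to compound 3. None of them has a readable size, and none brings in methylsulfonyl, so they offer only a shared limit and no trend to extend. No direction can be assigned, and no step beyond the scatter is expected. The expected outcome is a number no higher from compound 3 to compound 4 (the limit leaves the size open). This expectation rests on compound 3 at its limit of > 100000 nM. A further limit is the most likely report. The estimate for compound 4 is 100000 nM, with an expected range of 50000 nM to 200000 nM.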

Compound 4, half-maximal inhibitory concentration: > 100000 nM
Compound 4 was reported as a limit; the forecaster's own chance of this, stated with the estimate: 90%; the middle value lies on the limit itself.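

In this assay compound 4 gives only a limit, > 100000 nM. Its steps from compound 1, compound 2 and compound 3 therefore cannot be read, and all four compounds share one position: the limit of > 100000 nM in this assay, at which 4 of the 4 values shown sit.

None of the compounds shown has a number of its own in this assay, which leaves open whether the group on the amine nitrogen in the ring has any bearing on the read-out.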